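Three analogues of one core in a cytotoxicity readout

The compounds below may be only part of what the source reports. "The series", "measured", "known", "first", "only" and "open" are said of these compounds alone.

Compound 1 `Cc1ccc(NC(=O)c2ccc(CNC(=O)c3cccnc3)c(C(F)(F)F)c2)cc1Nc1nccc(-c2cccnc2)n1`, compound 2 `CCC(=O)Nc1ccc(C(=O)Nc2ccc(C)c(Nc3nccc(-c4cccnc4)n3)c2)cc1` and compound 3 `CCC(=O)Nc1cc(C(=O)Nc2ccc(C)c(Nc3nccc(-c4cccnc4)n3)c2)cc(C(F)(F)F)c1` share a common core and were tested in an ADME assay on BaF3 cells (Mus musculus) for cytotoxicity, read by CellTiter-Glo and CCK-8 assay, with a stated time of 72 h; a higher number here means a weaker inhibitor of growth, a lower number a stronger inhibitor of growth. In this assay compound 1 gives 8330 nM. For compound 2 the assay reports only a limit, > 10000 nM. For compound 3 the assay likewise reports only a limit, > 10000 nM. Compound 2 therefore sits at the weak end of what is shown, where the limit of > 10000 nM in this assay, at which 2 of the 3 values shown sit, marks the boundary of the measurement rather than a number.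

Compound 4 `CCCC(=O)N(CCN(C)C)Cc1ccc(C(=O)Nc2ccc(C)c(Nc3nccc(-c4cccnc4)n3)c2)cc1` has not yet been measured. It differs from compound 2 in a single place: ((2-(dimethylamino)ethyl)(propylcarbonyl)amino)methyl in place of propanoylamino on an aromatic carbon. The propanoylamino group leaves, and the ((2-(dimethylamino)ethyl)(propylcarbonyl)amino)methyl group enters on the same aromatic carbon, para to a large group.

Among the compounds with values here, with no measured step of comparable kind to lean on, the step from compound 2 to compound 4 in this assay is expected to be small, no larger than the usual scatter, and as likely to fall at the limit again as to yield a number; the expected step is an at least 1.2-fold lower number from compound 2 to compound 4 (0.09 log units; that floor lies within the scatter). Compound 4 is therefore estimated at 8000 nM, with a range from 2000 nM to 25000 nM.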

Compound 4, concentration for 50% growth inhibition: > 10000 nM
Compound 4: no number, only a limit; the forecaster's own chance of this, stated with the estimate: 45%; middle value at least 1.2-fold (0.09 log units) from the limit.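

Compound 2 and compound 4 each give only a limit, so no step between them can be read: the limit of > 10000 nM in this assay, at which 3 of the 4 values shown sit.

The compounds shown leave open whether ((2-(dimethylamino)ethyl)(propylcarbonyl)amino)methyl in place of propanoylamino on that aromatic carbon changes growth inhibition in this assay at all.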